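A few compounds are considered here, and "the series" means these few. Any claim that something is new, unique, unknown or untested is made for them only; others in the source may bear on it.

Compound 3 `CCCC(=O)N1CCC(NS(=O)(=O)c2ccc(NC(=O)c3ccc(CC)cc3)c3ccccc23)CC1` was run in an in vitro functional assay on CHO/Galpha16 cells for antagonist activity at C-C chemokine receptor type 8 (Homo sapiens), read by FLIPR (on this read-out higher numbers stand for weaker inhibition and lower numbers for stronger inhibition), where compound 3 gives 10.8 nM. Among the three compounds measured so far this is the second highest number. Compound 1 `CCCC(=O)N1CCC(NS(=O)(=O)c2ccc(NC(=O)c3ccc(C)cc3)c3ccccc23)CC1` gives 9.5 nM, and the step of a 1.1-fold higher number from compound 1 to compound 3 (0.06 log units; within the scatter) lies within the scatter of repeated measurements. Compound 2 `CCCC(=O)N1CCC(NS(=O)(=O)c2ccc(NC(=O)C(CC)CC)c3ccccc23)CC1` gives 639 nM, a much weaker inhibitor; the steps of a 67-fold higher number from compound 1 to compound 2 (1.83 log units; beyond the scatter) and a 59-fold lower number from compound 2 to compound 3 (1.77 log units; beyond the scatter) show that putting pentan-3-yl in place of the substituted phenyl group on the carbonyl carbon changes the number greatly, whereas lengthening the chain on that phenyl from methyl to ethyl did not.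

Compound 4 `CCCCc1ccc(C(=O)Nc2ccc(S(=O)(=O)NC3CCN(C(=O)CCC)CC3)c3ccccc23)cc1` has not yet been measured. It differs from compound 3 by ethyl in place of hydrogen on a saturated chain carbon, two bonds along the chain from an aromatic carbon. Within the data shown here, the one measured step of the same kind, a 1.1-fold higher number from compound 1 to compound 3 (0.06 log units; within the scatter), stayed within the scatter, so the expected step of a 1.4-fold higher number from compound 3 to compound 4 (0.14 log units; within the scatter) is small, with no clear direction beyond the scatter. Compound 4 is therefore expected to give about 15 nM in this assay, within a range from 5 nM to 45 nM.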

Compound 4, half-maximal inhibitory concentration: 15.3 nM
For compound 4 the middle estimate is 1.0-fold (0.01 log units) below the measured one; measured number inside the range.
By their numbers in this assay, from the lowest: compounds 1, 3 and 4 (each within the scatter of the next); then compound 2.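

Going from 4-ethylphenyl to 4-butylphenyl adds a further ethyl to the chain, and in this assay the result is a 1.4-fold higher number from compound 3 to compound 4 (0.15 log units; within the scatter). Even the whole extension from the methyl of compound 1 to butyl, a 1.6-fold higher number from compound 1 to compound 4 (0.21 log units; within the scatter), cannot be told from repeat-measurement noise, so this position accepts a chain as long as butyl without a measurable change. The large gap to the pentan-3-yl amide also survives this longer chain, at a 42-fold lower number from compound 2 to compound 4 (1.62 log units; beyond the scatter). Nothing available here explains why chain length makes so little difference.

On these data alone, it remains open whether this tolerance extends to a longer chain such as hexyl, or to an amine or a carboxylic acid in place of butyl. The compounds shown also leave open how a plain phenyl group, carrying no chain, would compare.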